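Replacing a longer amine side chain with diethylamino

This account rests on a few compounds, and the source may have more. Where it says the series, first, only, none or still open, it means among the compounds named here.

Three chalcone-type compounds have been measured in a functional assay on MCF7 cells (Homo sapiens) for antiproliferative activity, with a stated time of 72 h; on this read-out lower numbers stand for stronger inhibition and higher numbers for weaker inhibition. Compound 1 `CCN(C)Cc1c(OC)cc(OC)c(C(=O)/C=C/c2ccccc2Cl)c1O` gives 6800 nM. Compound 2 `COc1cc(OC)c2c(=O)cc(-c3ccccc3Cl)oc2c1CN1CCCCC1`, which carries a different core, gives 23700 nM. Compound 3 `COc1cc(OC)c(C(=O)/C=C/c2ccccc2Cl)c(O)c1CN(C)CCCN(C)C` gives 3200 nM, the lowest of the three numbers; the step of a 2.1-fold lower number from compound 1 to compound 3 (0.33 log units; beyond the scatter) separates it from compound 1, and compound 2 lies further away still.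

Compound 4 `CCN(CC)Cc1c(OC)cc(OC)c(C(=O)/C=C/c2ccccc2Cl)c1O` differs from compound 3 in one place: diethylamino in place of (3-(dimethylamino)propyl)(methyl)amino on a saturated chain carbon bound to an aromatic carbon. Among the compounds with values here, the one measured step that bears on this, a 2.1-fold lower number from compound 1 to compound 3 (0.33 log units; beyond the scatter), was modest and ran in the opposite direction, so taking the side chain away again and putting in diethylamino is expected to give back roughly what was gained, with the shorter group in compound 4 standing closer to compound 1 than to compound 3. Compound 4 is therefore expected to show a step of a 1.9-fold higher number from compound 3 to compound 4 (0.27 log units; within the scatter) in this assay, toward a higher number. The estimate for compound 4 is 6000 nM, within a range of 2500 nM to 14000 nM.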

Compound 4, half-maximal inhibitory concentration: 2700 nM
Estimate against measurement, compound 4: 2.2-fold (0.35 log units) above; low and high end bracket the measured number.
By their numbers in this assay, from the lowest: compounds 4 and 3 (each within the scatter of the next); then compound 1; then compound 2.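

In this assay the step of a 1.2-fold lower number from compound 3 to compound 4 (0.07 log units; within the scatter) lies within the scatter, so on a saturated chain carbon bound to an aromatic carbon, diethylamino (5 heavy atoms, 1 nitrogen) cannot be told apart from (3-(dimethylamino)propyl)(methyl)amino (8 heavy atoms, 2 nitrogens). For these two compounds, then, the longer side chain and its second nitrogen are not needed to reach this level, and the single methyl in place of hydrogen on a saturated chain carbon bound to an amine nitrogen gives a 2.5-fold lower number from compound 1 to compound 4 (0.40 log units; beyond the scatter) as a modest step beyond the scatter. No measurement at hand accounts for these readings.

Going by these compounds, whether a longer dialkylamine such as dipropylamino would hold this level remains open. So does the reading of a ring amine such as morpholine or piperidine on this same core.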